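The source may hold more compounds than are shown below. What is called first, only, known or untested is meant among the compounds shown, and "the series" means these compounds.

In a functional assay on MCF7 cells (Homo sapiens) for inhibition, read by MTT assay, with a stated time of 3 days (a higher number here means a weaker inhibitor, a lower number a stronger inhibitor), compound 1 (`COc1cc(-c2nc3ccccc3s2)ccc1OCC(=O)NNC(=O)CCl`) gives 780 nM, compound 2 (`COc1cc(-c2nc3ccccc3s2)ccc1OCC(=O)NNC(=O)CN[C@@H](CS)C(=O)O`) gives 1230 nM and compound 3 (`COc1cc(-c2nc3ccccc3s2)ccc1OCC(=O)NNC(=O)CN1CCC[C@H]1C(=O)O`) gives 840 nM on the same shared core. Compound 3 sits within the scatter of both others, with a 1.1-fold higher number from compound 1 to compound 3 (0.03 log units; within the scatter) and a 1.5-fold lower number from compound 2 to compound 3 (0.17 log units; within the scatter) as its two steps. Compound 4 (`CCOC(=O)[C@H](CS)NCC(=O)NNC(=O)COc1ccc(-c2nc3ccccc3s2)cc1OC`) alters one place, on a saturated chain carbon bound to a carbonyl carbon, where (1-(ethoxycarbonyl)-2-sulfanylethyl)amino in place of 2-carboxypyrrolidin-1-yl on a saturated chain carbon bound to a carbonyl carbon describes the swap. Within the data shown here, the entering group, (1-(ethoxycarbonyl)-2-sulfanylethyl)amino, matches the (1-carboxy-2-sulfanylethyl)amino of compound 2 except for ethoxycarbonyl in place of carboxy, and no measured compound carries ethoxycarbonyl. The nearest evidence is a 1.6-fold higher number from compound 1 to compound 2 (0.20 log units; within the scatter) together with the two steps above, all swaps at this same place and all within the scatter. From the compounds shown here alone, the direction therefore stays open, and the expected step in this assay is a 1.1-fold higher number from compound 3 to compound 4 (0.03 log units; within the scatter) with nothing beyond the scatter foreseen. For compound 4 the estimate is 900 nM with an expected range from 400 nM to 2000 nM around it.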

Compound 4, half-maximal inhibitory concentration: 2880 nM
Compound 4: the middle estimate sits 3.2-fold (0.51 log units) below what was measured; the whole stated range lies below it.
By their numbers in this assay, from the lowest: compounds 1, 3 and 2 (each within the scatter of the next); then compound 4.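

Among these compounds, at this place, on a saturated chain carbon bound to a carbonyl carbon, the earlier swaps all stayed within the scatter in this assay, so they did not separate the groups; the new side chain is the first to go beyond it, with a 3.4-fold higher number from compound 3 to compound 4 (0.54 log units; beyond the scatter) and a 3.7-fold higher number from compound 1 to compound 4 (0.57 log units; beyond the scatter). The closest comparison is ethyl in place of hydrogen on an oxygen next to a carbonyl group, which gives a 2.3-fold higher number from compound 2 to compound 4 (0.37 log units; beyond the scatter), so changing carboxy to ethoxycarbonyl, with the rest of the side chain kept, is enough to give a weaker inhibitor. Nothing available explains this loss.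

A methyl ester or a longer chain on that oxygen would show whether the size of the ester matters. The same ethyl ester on the 2-carboxypyrrolidin-1-yl group would show whether the step depends on the sulfanyl side chain.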